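Replacing the azepanyl amine of compound 3 with a pyridinylmethoxy ether

The source may hold more compounds than are shown below. What is called first, only, known or untested is meant among the compounds shown, and "the series" means these compounds.

The series shares an amide built on a methanesulfonamide-bearing aryl propanamide; activity is read in an assay on CHO cells for antagonist activity at transient receptor potential cation channel subfamily V member 1 (Homo sapiens), read by FLIPR; a lower number here means a stronger inhibitor, a higher number a weaker inhibitor. Compound 1 `CC1CCN(c2nc(C(F)F)ccc2CNC(=O)C(C)c2ccc(NS(C)(=O)=O)c(F)c2)CC1` gives 1 nM. Compound 2 `CC1CCN(c2nc(C3CC3)ccc2CNC(=O)C(C)c2ccc(NS(C)(=O)=O)c(F)c2)CC1` gives 0.9 nM. The step of a 1.1-fold lower number from compound 1 to compound 2 (0.05 log units; within the scatter) shows that this exchange of the ring substituent has no effect beyond scatter. Compound 3 `CC(C(=O)NCc1ccc(C(F)(F)Cl)nc1N1CCCCCC1)c1ccc(NS(C)(=O)=O)c(F)c1` gives 0.5 nM and so carries the lowest number of the three, though it lies within the scatter of both compound 2 and compound 1, so no order among them can be claimed.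

Compound 4 `CC(C(=O)NCc1ccc(C(F)(F)Cl)nc1OCc1cccnc1)c1ccc(NS(C)(=O)=O)c(F)c1` differs from compound 3 in one place: (pyridin-3-yl)methoxy in place of azepan-1-yl on an aromatic carbon. Among the measured compounds shown here, no measured step touches this position; the only step recorded, from compound 1 to compound 2, concerns the substituent on the other side of the core and was itself within scatter. The exchange of a cyclic amine for an aryl ether at this position is a larger change than anything measured, so a move toward a higher number by an 8.0-fold higher number from compound 3 to compound 4 (0.90 log units; beyond the scatter) is expected, with a wide range. Compound 4 is estimated at 4 nM, between 0.8 nM and 25 nM.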

Compound 4, inhibition constant: 14.6 nM
Compound 4: middle estimate off by 3.7-fold (0.56 log units), on the low side, and the stated range covers the measured number.
By their numbers in this assay, from the lowest: compounds 3, 2 and 1 (each within the scatter of the next); then compound 4.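

The step of a 29-fold higher number from compound 3 to compound 4 (1.47 log units; beyond the scatter) in this assay shows that this position, on an aromatic carbon next to the ring nitrogen, responds to its substituent, whereas the exchange on the other side of the core, a 1.1-fold lower number from compound 1 to compound 2 (0.05 log units; within the scatter), did not move the number beyond the scatter. Closeness in heavy-atom count between azepan-1-yl and (pyridin-3-yl)methoxy does not keep the number low, so size alone does not decide what this position accepts. Nothing measured here bears on why the number rises.

The compounds shown leave open whether the rise goes with the oxygen link or with the aromatic ring, as both change together in this single exchange. Cyclohexylmethoxy at this position would separate those two, and benzyloxy would test the pyridine ring nitrogen.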